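The source may report more compounds than this note shows. Statements on the series, on what has been measured and on what is new or still open speak of the compounds shown alone.

Measured so far:
compound 1 `COc1cccc(-c2c(C)n(Cc3c(F)cccc3F)c(=O)n(C[C@@H](N)CCc3ccccc3)c2=O)c1F` gives 965 nM in an assay on HEK293 cells for binding affinity to Gonadotropin-releasing hormone receptor (Homo sapiens), read by radioligand binding; on this read-out higher numbers stand for weaker inhibition and lower numbers for stronger inhibition;
compound 2 `COc1cccc(-c2c(C)n(Cc3c(F)cccc3F)c(=O)n(C[C@@H](N)C(C)C)c2=O)c1F` gives 973 nM;
compound 3 `COc1cccc(-c2c(C)n(Cc3c(F)cccc3F)c(=O)n(C[C@@H](N)C3CCCCC3)c2=O)c1F` gives 46 nM.

Compound 1 stands second highest of the three, with compound 2 at a 1.0-fold higher number from compound 1 to compound 2 (0.00 log units; within the scatter) and compound 3 at a 21-fold lower number from compound 1 to compound 3 (1.32 log units; beyond the scatter). Compound 4 `COc1cccc(-c2c(C)n(Cc3c(F)cccc3F)c(=O)n(C[C@H](N)C3CCCCC3)c2=O)c1F` is unmeasured; it differs from compound 1 by amino(cyclohexyl)methyl in place of 1-amino-3-phenylpropyl on a saturated chain carbon bound to an aromatic nitrogen. Among the compounds with values here, compound 4 carries the same group as compound 3 but with the opposite configuration at its stereocentre, and no measured pair shows what such a configuration change does. The relevant steps are a 21-fold lower number from compound 1 to compound 3 (1.32 log units; beyond the scatter) and a 21-fold lower number from compound 2 to compound 3 (1.33 log units; beyond the scatter), both large. A drop in this assay is therefore expected for compound 4, but smaller than that of compound 3 and with wide uncertainty, giving an estimated 3.2-fold lower number from compound 1 to compound 4 (0.51 log units; beyond the scatter). Compound 4 is estimated at 300 nM, within 40 nM to 2500 nM.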

Compound 4, inhibition constant: 6.5 nM
Estimate against measurement, compound 4: 46-fold (1.66 log units) above, outside the stated range (below it).
By their numbers in this assay, from the lowest: compound 4; then compound 3; then compounds 1 and 2 (each within the scatter of the next).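

In this assay, the configuration at this saturated chain carbon proves to matter, with a 7.1-fold lower number from compound 3 to compound 4 (0.85 log units; beyond the scatter), and this step can be assigned to the stereocentre alone: the fact that compounds 3 and 4 differ only in the configuration as drawn. Set against the other two side chains, amino(cyclohexyl)methyl in this configuration gives a 150-fold lower number from compound 1 to compound 4 (2.17 log units; beyond the scatter) and a 150-fold lower number from compound 2 to compound 4 (2.18 log units; beyond the scatter), both large. The benefit of cyclohexyl thus depends on how the group is drawn at the stereocentre.

From the compounds shown here alone, whether the same inversion changes the values with 1-amino-3-phenylpropyl or 1-amino-2-methylpropyl remains open. So does the outcome with a cyclopentyl or phenyl ring, or a methylated amine, at this carbon.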